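The source may report more compounds than this note shows. Statements on the series, on what has been measured and on what is new or still open speak of the compounds shown alone.

Measured in a functional assay on Hs68 cells (Homo sapiens) for cytotoxicity; a lower number here means that less compound is tolerated, a higher number that more compound is tolerated:
- compound 1 `O=C(NCc1cccc(Br)c1)c1ccc2cnccc2n1`: 50 ug/mL
- compound 2 `CC(C)Oc1ccccc1CNC(=O)c1ccc2cnccc2n1`: 2.5 ug/mL
- compound 3 `CC[C@@H](C)Oc1ccccc1CNC(=O)c1ccc2cnccc2n1`: 0.1 ug/mL

Compound 3 has the lowest number of the three, so the least of it is tolerated in this assay. Compound 4 `O=C(NCc1ccccc1)c1ccc2cnccc2n1` differs from it by hydrogen in place of sec-butoxy on an aromatic carbon. The measured step that bears most directly on this is a 25-fold lower number from compound 2 to compound 3 (1.40 log units; beyond the scatter), a large one that came with a single added methyl on this side group. Removing the whole group should therefore also move the number a long way, and upward, since compound 1, which lacks the group, gives 50 ug/mL. The expected change is a 300-fold higher number from compound 3 to compound 4 (2.48 log units; beyond the scatter). For compound 4 the estimate is 30 ug/mL, with an expected range from 6 ug/mL to 100 ug/mL.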

Compound 4, half-maximal cytotoxic concentration: 71 ug/mL
For compound 4 the middle estimate is 2.4-fold (0.37 log units) below the measured one; measured number inside the range.
By their numbers in this assay, from the lowest: compound 3; then compound 2; then compounds 1 and 4 (each within the scatter of the next).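

Removing sec-butoxy from the aromatic ring gives a 710-fold higher number from compound 3 to compound 4 (2.85 log units; beyond the scatter) and removing isopropoxy gives a 28-fold higher number from compound 2 to compound 4 (1.45 log units; beyond the scatter), so in these compounds the low numbers go with the ether side groups and not with the shared core. Bromo makes no such difference: hydrogen in its place gives a 1.4-fold higher number from compound 1 to compound 4 (0.15 log units; within the scatter). Nothing measured here explains why the ether groups have so large an effect. On these data alone, it remains open how small the ether can become before the number climbs, for instance with methoxy, and whether an amine in this place would behave like the ethers.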